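Swapping a Pentyl Chain for Isopropoxy on a Sulfonyl Benzoylguanidine

The source may report more compounds than this note shows. Statements on the series, on what has been measured and on what is new or still open speak of the compounds shown alone.

Measured compounds:
Compound 1, `CCc1cc(Cl)c(S(C)(=O)=O)cc1C(=O)N=C(N)N`: in a functional assay for inhibition of sodium/hydrogen exchanger (Oryctolagus cuniculus) (on this read-out lower numbers stand for stronger inhibition and higher numbers for weaker inhibition), compound 1 gives 63 nM.
Compound 2, `CCN(CC)Cc1cc(Br)c(S(C)(=O)=O)cc1C(=O)N=C(N)N`: in this assay compound 2 gives 9500 nM.
Compound 3, `CCCCCc1cc(C)c(C(=O)N=C(N)N)cc1S(C)(=O)=O`: in this assay compound 3 gives 27 nM.

Compound 3 shows the lowest number of the three, so it is the strongest inhibitor here; compound 1 comes closest, and compound 2 stands far weaker. Compound 4, `Cc1cc(OC(C)C)c(S(C)(=O)=O)cc1C(=O)N=C(N)N`, has not yet been measured. It differs from compound 3 in one place: isopropoxy in place of pentyl on an aromatic carbon. The pentyl chain is lost and a shorter group carrying one oxygen takes its place, while the methyl group and the shared core stay unchanged. Among the compounds with values here, no measured pair shows this kind of change, so the step is estimated from compound 3 alone, and a modest weakening is expected, a 3.7-fold higher number from compound 3 to compound 4 (0.57 log units; beyond the scatter), likely a little beyond the scatter. Compound 4 is therefore expected to give about 100 nM, somewhere between 25 nM and 400 nM.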

Compound 4, half-maximal inhibitory concentration: 19 nM
Compound 4: the middle estimate sits 5.3-fold (0.72 log units) above what was measured; measured number outside the range, below it.
By their numbers in this assay, from the lowest: compounds 4 and 3 (each within the scatter of the next); then compound 1; then compound 2.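

This position, ortho to the methylsulfonyl group, takes isopropoxy in place of pentyl with no loss that can be told from the scatter: a 1.4-fold lower number from compound 3 to compound 4 (0.15 log units; within the scatter). So the pentyl chain, with its 5 carbon atoms, is not needed for strong inhibition in this series, and a group of 4 heavy atoms that includes an oxygen serves equally well. Nothing measured here explains why the two groups match. Still open, going by these compounds, is whether a smaller methoxy, a longer chain or an amine at this position would also keep inhibition.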